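Half-life of a pyrazine-free estimate

The compounds below may be only part of what the source reports. "The series", "measured", "known", "first", "only" and "open" are said of these compounds alone.

Oops, corrected title below.

Side-chain swap on the shared core

Measured in an in vitro ADME assay on microsomes (Homo sapiens) for metabolic stability; a lower number here means that the compound disappears faster, a higher number that the compound lasts longer:
Compound 1 `CCc1nc(-c2ccc(Cl)cc2Cl)c(CC)nc1CC(CC)CC`: 0.217 h
Compound 2 `CCc1nc(-c2ccc(Cl)cc2Cl)c(CC)nc1NC(C)CN(C)C`: 0.117 h

Within the data shown here, only two compounds have been measured so far, and compound 2, at 0.117 h, lies within the scatter of the other one. Compound 3 `CCCN(CCN(C)C)c1nc(CC)c(-c2ccc(Cl)cc2Cl)nc1CC` has not yet been measured. It carries (2-(dimethylamino)ethyl)(propyl)amino in place of (1-((dimethylamino)methyl)ethyl)amino on an aromatic carbon. Among the measured compounds shown here, one measured step bears on this change, as it also replaced a group on an aromatic carbon, there 2-ethylbutyl giving way to (1-((dimethylamino)methyl)ethyl)amino. That step stayed within the scatter: a 1.9-fold lower number from compound 1 to compound 2 (0.27 log units; within the scatter). For the measured compounds named here, it is a single step, and no measured compound shows the effect of a propyl group on the amino nitrogen. A change from one amino chain to another is therefore expected to shift this assay by no more than the scatter, with no firm direction. The expected step is a 1.2-fold lower number from compound 2 to compound 3 (0.07 log units; within the scatter). For compound 3 the estimated value is 0.1 h, with an expected range of 0.05 h to 0.21 h.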

Compound 3, half-life: 0.0833 h
Compound 3: middle estimate off by 1.2-fold (0.08 log units), on the high side, and the stated range covers the measured number.
By their numbers in this assay, from the lowest: compounds 3, 2 and 1 (each within the scatter of the next, the first and the last beyond it).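

In this assay, setting (2-(dimethylamino)ethyl)(propyl)amino in place of (1-((dimethylamino)methyl)ethyl)amino on this aromatic carbon gives a step that stays within the scatter (a 1.4-fold lower number from compound 2 to compound 3 (0.15 log units; within the scatter)), so these two amino chains cannot be told apart here, although the entering chain has 0 hydrogen-bond donors and the leaving chain has 1. The comparison with 2-ethylbutyl now reads differently: the earlier step to an amino chain stayed within the scatter, whereas this one passes it (a 2.6-fold lower number from compound 1 to compound 3 (0.42 log units; beyond the scatter)), the first modest separation seen at this position. Nothing available gives a reason for either step.

The compounds shown leave open whether the step beyond the scatter belongs to amino chains at this position in general or to this chain alone, and whether the propyl group on the amino nitrogen contributes anything by itself. From the compounds shown here alone, it also remains open how a methyl group on that nitrogen, a morpholine in place of the terminal dimethylamino group, or a carboxylic acid at the end of the chain would read in this assay on the shared core.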